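This account rests on a few compounds, and the source may have more. Where it says the series, first, only, none or still open, it means among the compounds named here.

Within the data shown here, in a functional assay on HeLa cells (Homo sapiens) for inhibition (a higher number here means a weaker inhibitor, a lower number a stronger inhibitor), only one of the three compounds tested so far has a numerical result. Compound 1 `CC(C)C(NC(=O)NO)C(=O)NC1CCCCC1` reaches only a limit of the assay, > 100000 nM. Compound 2 `CCC(C)C1NC(=O)N(C2CCCC2)C1=O` also reaches only a limit, > 100000 nM. Compound 3 `CCC(C)C(NC(=O)n1nnc2ccccc21)C(=O)NC(c1ccccc1)c1ccccc1` gives an actual number, 60000 nM, which marks it as a weak inhibitor. Compound 4 `CCC(C)C(NC(=O)n1nnc2ccccc21)C(=O)NCc1ccccc1` changes compound 3 in one place: hydrogen in place of phenyl on a saturated chain carbon bound to an amide-type nitrogen and an aromatic carbon, with hydrogen in place of phenyl on a saturated chain carbon bound to an amide-type nitrogen and an aromatic carbon. Among the measured compounds shown here, no tested pair shows this change, so the forecast is uncertain. A small expected shift toward weaker inhibition, possibly within the scatter, is a 1.5-fold higher number from compound 3 to compound 4 (0.18 log units; within the scatter). Compound 4 is estimated at 90000 nM, with an expected range of 40000 nM to 200000 nM.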

Compound 4, half-maximal inhibitory concentration: >= 100000 nM
Compound 4 was reported as a limit (the forecaster's own chance of this, stated with the estimate: 55%); at least 1.1-fold (0.04 log units) between middle value and limit.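

In this assay the first step shown at this place, hydrogen in place of phenyl on a saturated chain carbon bound to an amide-type nitrogen and an aromatic carbon, is an at least 1.6-fold higher number from compound 3 to compound 4 (0.22 log units; that floor lies within the scatter) and gives no sign of stronger inhibition without the phenyl. Compound 4 gives >= 100000 nM as a limit of the assay, not a number. The full size of the step cannot be read, because compound 4 sits at a limit: the limit of >= 100000 nM in this assay, at which 1 of the 4 values shown sits.

Still open, as far as these compounds go, is whether another group at this place, such as methyl or cyclohexyl, would give a lower number in this assay than the phenyl does.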